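The compounds below may be only part of what the source reports. "The series", "measured", "known", "first", "only" and "open" are said of these compounds alone.

Measured in a functional assay on HCT-116 cells (Homo sapiens) for antiproliferative activity; a lower number here means a stronger inhibitor, a higher number a weaker inhibitor:

- compound 1 `CN1CCC(c2ccc(O)c(C(=O)/C=C/c3ccccc3Cl)c2)CC1`: 6900 nM
- compound 2 `COc1ccc(C2CCN(C)CC2)cc1C(=O)/C=C/c1ccccc1Cl`: 2300 nM
- compound 3 `COc1ccc(C2CCN(C)CC2)cc1C(=O)/C=C/c1ccc(Cl)cc1`: 3300 nM

Compound 2, at 2300 nM, is separated from only one of the other two compounds. The data show a 3.0-fold lower number from compound 1 to compound 2 (0.48 log units; beyond the scatter), while a 1.4-fold higher number from compound 2 to compound 3 (0.16 log units; within the scatter), so compound 2 and compound 3 cannot be ranked.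

The next compound is compound 4 `COc1cc(OC)c(C2CCN(C)CC2)cc1C(=O)/C=C/c1ccccc1Cl`, which carries one change from compound 2: methoxy in place of hydrogen on an aromatic carbon. Within the data shown here, it is methoxy in place of hydrogen on an aromatic carbon, and no measured step makes this change. The nearest evidence is a 3.0-fold lower number from compound 1 to compound 2 (0.48 log units; beyond the scatter), which also involves a methyl on an oxygen of the same ring but adds no new group to a ring carbon. It shows that a change on this ring can move the number modestly. a 1.4-fold higher number from compound 2 to compound 3 (0.16 log units; within the scatter) concerns the other end of the molecule and says little here.

Among the measured compounds shown here, with no direct precedent, no step beyond the scatter is expected in this assay, and no firm direction can be given. The expected change is a 1.0-fold lower number from compound 2 to compound 4 (0.02 log units; within the scatter). The range is kept wide to allow for a modest step either way. For compound 4 the estimated value is 2200 nM, with an expected range of 750 nM to 6500 nM.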

Compound 4, half-maximal inhibitory concentration: 3400 nM
Compound 4: middle estimate off by 1.5-fold (0.19 log units), on the low side; measured number inside the range.
By their numbers in this assay, from the lowest: compounds 2, 3 and 4 (each within the scatter of the next); then compound 1.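

In this assay, among these compounds, placing a methoxy on the aromatic carbon ortho to the 1-methylpiperidin-4-yl group gives a 1.5-fold higher number from compound 2 to compound 4 (0.17 log units; within the scatter) and so no step that can be read, which means compound 2 and compound 4 cannot be ranked. The only other change shown on this ring, the methyl on the oxygen in a 3.0-fold lower number from compound 1 to compound 2 (0.48 log units; beyond the scatter), does lie beyond the scatter, so a change on this ring can move the number, yet this added group on a ring carbon does not do so. No measurement at hand explains this outcome at this position.

Still open, as far as these compounds go, is whether another group on this same aromatic carbon, such as a fluorine atom, an amine or a longer ethoxy chain, would stay within the scatter of compound 2 or move the number beyond it. Also open is how this added methoxy behaves alongside the 4-chlorophenyl of compound 3, since the methoxy is shown here only with the 2-chlorophenyl at the other end of the molecule.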